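The source may hold more compounds than are shown below. What is called first, only, known or untested is meant among the compounds shown, and "the series" means these compounds.

Measured so far in an ADME assay on MIA PaCa-2 cells (Homo sapiens) for cytotoxicity, read by MTT assay, with a stated time of 72 h; a higher number here means a weaker inhibitor, a lower number a stronger inhibitor:

compound 1 `COc1ccc(C2=C(c3cc(OC)c(OC)c(OC)c3)C(=O)C(OC(C)=O)C2)cc1F`, 39.5 ug/mL
compound 2 `COc1ccc(C2=C(c3cc(OC)c(OC)c(OC)c3)C(=O)C(O)C2)cc1Cl`, > 100 ug/mL
compound 3 `COc1ccc(C2=C(c3cc(OC)c(OC)c(OC)c3)C(=O)C(O)C2)cc1F`, 64 ug/mL

Compound 4 `COc1ccc(C2=C(c3cc(OC)c(OC)c(OC)c3)C(=O)C(OC(C)=O)C2)cc1Cl` has not yet been measured in this assay.

The value given for compound 2 is a limit of the assay, not a number; it sits at the limit of > 100 ug/mL in this assay, at which 1 of the 3 values shown sits.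

Compound 1 and compound 3 share a core and differ only in the change (acetyl in place of hydrogen on an oxygen on a saturated carbon). That change gave a 1.6-fold lower number from compound 3 to compound 1 (0.21 log units; within the scatter).

Compound 2 and compound 4 share a core that differs from the core of compound 3 and compound 1 by chloro in place of fluoro on an aromatic carbon. Between compound 2 and compound 3 the step is an at least 1.5-fold lower number from compound 2 to compound 3 (0.19 log units; that floor lies within the scatter).

Compound 4 stands to compound 2 as compound 1 stands to compound 3: the change is acetyl in place of hydrogen on an oxygen on a saturated carbon, at the same place as before, so it is the same change. Since the step from compound 3 to compound 1 lay within the scatter, the step from compound 2 to compound 4 is expected to be about a number no higher from compound 2 to compound 4 (the limit leaves the size open), resting on the size of the step from compound 3 to compound 1 and on the limit seen for compound 2. Compound 4 is therefore estimated at 100 ug/mL in this assay, in the range 50 ug/mL to 220 ug/mL, with a fair chance that the assay again reports only a limit.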

Compound 4, half-maximal inhibitory concentration: 24 ug/mL
Compound 4: the middle estimate sits 4.2-fold (0.62 log units) above what was measured; measured number below the stated range.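

Compound 2 reads > 100 ug/mL in this assay, which is a limit of the assay and not a number. On the core of compound 2, acetyl in place of hydrogen on the oxygen gives an at least 4.1-fold lower number from compound 2 to compound 4 (0.61 log units; beyond the scatter), a step that is clear of the scatter, whereas the same change on the core of compound 1 stays within it. This pair of results shows that the change can give a real step on one core, but it does not show that the size of the step carries from one core to the other: the same change on two cores in this assay, a 1.6-fold lower number (0.21 log units; within the scatter) from compound 3 to compound 1 and an at least 4.1-fold lower number (0.61 log units; beyond the scatter) from compound 2 to compound 4; the limit leaves it open whether they differ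

With acetoxy in place on both compounds, chloro in place of fluoro gives a 1.6-fold lower number from compound 1 to compound 4 (0.22 log units; within the scatter), so these compounds do not separate the two halogens. Still open, on these data alone, is whether the step belongs to acetyl alone or would also appear with a longer acyl chain, an amine or a carboxylic acid at that oxygen-bearing carbon, and whether it holds on cores carrying other groups in place of chloro or fluoro.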